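Swapping a Five-Membered Amine Ring for a Six-Membered One

The source may report more compounds than this note shows. Statements on the series, on what has been measured and on what is new or still open speak of the compounds shown alone.

Compound 1 `O=C(c1ccccc1)c1sc(N2CCCC2)nc1Cl` and compound 2 `O=C(c1ccccc1)c1sc(N2CCCCC2)nc1Cl` share one core; compound 3 `COC(=O)c1sc2nc(N3CCCC3)sc2c1C` and compound 4 `COC(=O)c1sc2nc(N3CCCCC3)sc2c1C` share another, and the difference between the two cores is not broken down here. In a functional assay on MCF7 cells (Homo sapiens) for cytotoxicity, read by MTT assay, with a stated time of 72 h (a higher number here means a weaker inhibitor, a lower number a stronger inhibitor), compound 1 gives 63000 nM, and compound 2 gives 56000 nM, so the step of a 1.1-fold lower number from compound 1 to compound 2 (0.05 log units; within the scatter) is small. That step is the change (piperidin-1-yl in place of pyrrolidin-1-yl on an aromatic carbon). In this assay compound 3 gives 56000 nM. Compound 4 carries the same kind of change, (piperidin-1-yl in place of pyrrolidin-1-yl on an aromatic carbon); the surroundings differ in that the ring here is part of a fused or bridged system of two rings, whereas in compound 1 the ring atom two ring bonds away bears a chloro group and another bears a group of 8 heavy atoms. Because the step of a 1.1-fold lower number from compound 1 to compound 2 (0.05 log units; within the scatter) stayed within the scatter, compound 4 is expected to shift by about a 1.1-fold lower number from compound 3 to compound 4 (0.05 log units; within the scatter). Compound 4 is therefore estimated at 50000 nM, between 25000 nM and 100000 nM.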

Compound 4, half-maximal inhibitory concentration: 90000 nM
For compound 4 the middle estimate is 1.8-fold (0.26 log units) below the measured one; the measured number falls inside the stated range.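

In this assay, putting piperidin-1-yl in place of pyrrolidin-1-yl on the second core gives a 1.6-fold higher number from compound 3 to compound 4 (0.21 log units; within the scatter), so here too the swap stays within the usual scatter of repeated measurements. Set side by side, the two steps do not differ by more than such scatter allows: the same change on two cores in this assay, a 1.1-fold lower number (0.05 log units; within the scatter) from compound 1 to compound 2 and a 1.6-fold higher number (0.21 log units; within the scatter) from compound 3 to compound 4, 1.8-fold (0.26 log units) apart, within the scatter of two such steps. The change therefore carries over between these two cores without a detectable difference, but two pairs cannot show that it would stay this small on any other core.

The compounds shown leave open what other amines would do at this place, such as morpholin-4-yl or an open-chain dimethylamino group. On these data alone, a comparison of the two cores themselves also stays open, as compounds on different cores differ in more than one place.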